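Dropping the methoxy from a coumarin-type amide

The compounds below may be only part of what the source reports. "The series", "measured", "known", "first", "only" and "open" are said of these compounds alone.

Measured compounds:
compound 1, `N=c1oc2ccc(Br)cc2cc1C(=O)NC1CCCCC1`: 10%
compound 2, `COc1cccc2cc(C(=O)NCC(=O)O)c(=O)oc12`: 35%
compound 3, `O=C(NCC(O)CO)c1cc2cc(Cl)ccc2oc1=O`: 23%

Three compounds sharing a core were tested in an assay on HEK293 cells for displacement of a labelled ligand from adenosine receptor A2b (Homo sapiens), read by scintillation counting, with a stated time of 30 min, tested at 10 uM; on this read-out higher numbers stand for more inhibition at the one concentration tested (going by the name of the read-out) and lower numbers for less inhibition. Compound 1 gives 10%, compound 3 gives 23%, and compound 2 gives 35%. Compound 2 thus stands highest of the three numbers: its gap to compound 3 lies beyond the scatter, and its gap to compound 1 lies further beyond it. None of these three pairs differs in only one place, so no single step can be read from them.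

Compound 4, `O=C(O)CNC(=O)c1cc2ccccc2oc1=O`, has not yet been measured in this assay. It differs from compound 2 as follows: hydrogen in place of methoxy on an aromatic carbon. For the measured compounds named here, no measured pair shows what this change does on the shared core, so the expectation rests only on the values of compound 2 and its neighbours. The step of a number 10 percentage points lower from compound 2 to compound 4 (within the scatter) is expected to be a modest fall, possibly not beyond the scatter. Compound 4 is therefore estimated at 25%, within a range from 5% to 45% in this assay.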

Compound 4, a percentage reported as inhibition, at one concentration (the size of the read-out at that concentration, not a potency): 9%
Beside the measured number, compound 4's estimate is 16 percentage points above it; low and high end bracket the measured number.
By their numbers in this assay, from the lowest: compounds 4 and 1 (each within the scatter of the next); then compound 3; then compound 2.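

In this assay, putting hydrogen in place of methoxy gives a number 26 percentage points lower from compound 2 to compound 4 (beyond the scatter), so the methoxy on this aromatic carbon, ortho to a fused ring and meta to a fused ring, makes a difference on this core. For the compounds shown here, none of the earlier pairs differed in only one place, so this is the first change whose size can be read on its own. Nothing measured here bears on why the number falls with this change.

The compounds shown leave open whether a hydroxyl, an ethoxy or an amine on the same carbon would give a number closer to that of compound 2 or of compound 4. They also leave open whether the methoxy would count for as much with a different chain on the amide.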